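The source may hold more compounds than are shown below. What is called first, only, known or untested is meant among the compounds shown, and "the series" means these compounds.

Measured so far in a functional assay on MGC-803 cells (Homo sapiens) for cytotoxicity, read by MTT assay, with a stated time of 72 h (a lower number here means a stronger inhibitor, a higher number a weaker inhibitor), are three compounds
- compound 1 `CCC(C)=C1C(=O)N(c2ccc(Cl)cc2)N(c2ccc(Cl)cc2)C1=O` gives 66500 nM 
- compound 2 `O=C1C(=Cc2ccc(Cl)cc2)C(=O)N(c2ccc(Cl)cc2)N1c1ccc(Cl)cc1` gives 32600 nM 
- compound 3 `COc1cc(C=C2C(=O)N(c3ccc(Cl)cc3)N(c3ccc(Cl)cc3)C2=O)cc(OC)c1OC` gives 17300 nM 

The number for compound 2 is the second highest of the three. It lies within the scatter of compound 3, while compound 1 stands apart from compound 2 by a gap just beyond the scatter.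

Compound 4 `COc1ccc(C=C2C(=O)N(c3ccc(Cl)cc3)N(c3ccc(Cl)cc3)C2=O)cc1` has not yet been measured. It differs from compound 2 in one place methoxy in place of chloro on an aromatic carbon with methoxy in place of chloro on an aromatic carbon, so that 4-chlorophenyl becomes 4-methoxyphenyl. Going by the values given here, no two measured compounds differ in one place only, which leaves this change without a direct precedent. Among the compounds with values here, compound 3 is the only measured compound bearing methoxy groups, and compound 3 at 17300 nM sits within the scatter of compound 2 at 32600 nM and so gives no sign of a large shift. The expected step of a 1.3-fold lower number from compound 2 to compound 4 (0.12 log units; within the scatter) is therefore none beyond the scatter. The estimate for compound 4 is 25000 nM with an expected range from 11000 nM to 55000 nM in this assay when it is measured.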

Compound 4, half-maximal inhibitory concentration: > 128000 nM
Compound 4: a limit, no number; the forecaster's own chance of this, stated with the estimate: 4%; middle value at least 5.1-fold (0.70 log units) from the limit.
By their numbers in this assay, from the lowest: compounds 3 and 2 (each within the scatter of the next); then compound 1. At a limit, above all of these: compound 4.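

Going by these compounds alone, the change from 4-chlorophenyl to 4-methoxyphenyl gives an at least 3.9-fold higher number from compound 2 to compound 4 (0.59 log units; beyond the scatter), the first comparison here in which only one place differs, and it shows that this position on the aromatic ring is not indifferent to the group it carries. In this assay compound 4 gives > 128000 nM, which is a limit of the assay and not a number. The step therefore fixes a direction and a smallest size, not a true size: the limit of > 128000 nM in this assay, at which 1 of the 4 values shown sits.

Compound 3 also carries methoxy groups and gives 17300 nM, but it differs from compound 4 in more than one place, so the two cannot be set against each other. As far as these compounds go, whether an amine, a carboxylic acid or a fluoro group in place of chloro on this carbon would keep or lose the activity of compound 2 remains open.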